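Ring Nitrogen Substituent Removal in a Propanamide Series

The source may report more compounds than this note shows. Statements on the series, on what has been measured and on what is new or still open speak of the compounds shown alone.

Measured compounds:
compound 1, `CCC(=O)NCC1CCc2c(OC)cccc2N1C`: 112%
compound 2, `CCC(=O)NCC1CCc2ccccc2N1CC(=O)NC`: "not determined" (no result reported)
compound 3, `CCC(=O)NCC1CCc2ccc(OC)cc2N1Cc1ccccc1`: "not determined" (no result reported)

The single read-out here is a functional assay on CHO cells with melatonin receptor type 1A (Homo sapiens) as the target, read by GTPgammaS binding, with a stated time of 1 h; a higher number here means a larger maximal response, a lower number a smaller maximal response. Among the measured compounds shown here, compound 1 is the only compound with a number; in this assay compound 1 gives 112%, a full response relative to the reference. For the measured compounds named here, compound 2 stands nowhere on the numbers: in this assay compound 2 is recorded as "not determined" (no result reported), and compound 3 likewise as "not determined" (no result reported), so the series has no measured step and no anchor for the effect of the substituent on the ring nitrogen.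

The step of interest runs from compound 2 to compound 4, `CCC(=O)NCC1CCc2ccccc2N1`. The change is hydrogen in place of (methylcarbamoyl)methyl on a nitrogen on an aromatic ring in a ring.

Going by the values given here, with compound 2 lacking a number, the step from compound 2 to compound 4 in this assay cannot be sized from data; the expectation is a change of no more than the usual scatter, in no set direction, because the only reference point is compound 1 at 112%. Compound 4 is therefore expected to give about 95% in this assay, with an estimated range of 60% to 120%.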

Compound 4, largest response reached (Emax), in percent of the reference or control that the assay uses: 37%
For compound 4 the middle estimate is 58 percentage points above the measured one, outside the stated range (below it).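

In this assay, among the compounds shown here, compound 2 has no single number, and no step from it to compound 4 can be read. The compounds shown leave open what the substituent on the ring nitrogen contributes to the maximal response. No supporting evidence bears on this result.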